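The compounds below may be only part of what the source reports. "The series", "measured", "known", "first", "only" and "open" are said of these compounds alone.

Of the compounds shown here, three built on the same amino-bearing core have been measured in a functional assay on the whole organism for inhibition, with Rattus norvegicus as the target, at a dose of 30 mg/kg; a lower number here means less inhibition, a higher number more inhibition at the dose given (going by the name of the read-out). Compound 1 `Nc1ncnn1/C(S)=N/C1CCCCC1` gives 31%, compound 2 `Nc1ncnn1/C(S)=N/CCCCCO` gives -17%, and compound 3 `C/N=C(\S)n1nc(-c2ccc(C#N)cc2)nc1N` gives 87%. Compound 3 therefore stands highest of the three, beyond the scatter of both others. Compound 4 `C/N=C(\S)Nc1ccc(-c2nc(N)n(/C(S)=N/C)n2)cc1` has not yet been measured; it differs from compound 3 by a single change, (a group of 5 heavy atoms (2 carbon, 2 nitrogen, 1 sulfur; no ring) in place of a group of 2 heavy atoms (1 carbon, 1 nitrogen; no ring), on an aromatic carbon), placed para to a large group. Among the measured compounds shown here, no measured pair shows a change of this kind, so its effect is uncertain; a moderate fall is expected, though a change within the scatter cannot be ruled out. In this assay compound 4 is expected to give 70%, in the range 40% to 90%. The expected step of a number 17 percentage points lower from compound 3 to compound 4 (beyond the scatter) is thus a modest decrease.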

Compound 4, a percentage reported as inhibition, in the whole organism at one dose (the size of the read-out at that dose, not a potency): 31%
Compound 4: middle estimate off by 39 percentage points, on the high side, and the stated range ends above it.
By their numbers in this assay, from the lowest: compound 2; then compounds 1 and 4 (each within the scatter of the next); then compound 3.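

In this assay, putting the larger sulfur-bearing group in place of cyano on the aromatic carbon, para to a large group, gives a number 56 percentage points lower from compound 3 to compound 4 (beyond the scatter). Among the compounds shown here, this is the first single-place change, and it shows that the group at this position matters to the read-out. No measurement shown here explains the loss. One pair cannot separate the effect of the added size from that of the added hydrogen-bond donors. An amine, a methoxy or a carboxylic acid at this position would help to tell them apart.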